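Swapping Benzyl for Isopropyl on the Aromatic Nitrogen

The compounds below may be only part of what the source reports. "The series", "measured", "known", "first", "only" and "open" are said of these compounds alone.

Compound 1 `Cc1ccc(-c2cnc(N(Cc3ccccc3)Cc3ccc(C(=O)NO)cc3)s2)cc1` is the starting point. In a functional assay on HepG2 cells (Homo sapiens) for antiproliferative activity, read by MTT assay, with a stated time of 48 h (on this read-out lower numbers stand for stronger inhibition of growth and higher numbers for weaker inhibition of growth), compound 1 gives 34000 nM, the highest of the three numbers measured here, meaning the weakest inhibition of growth among them. Two relatives replace the phenyl part of the benzyl group with a plain chain. Compound 2 `CCCCN(Cc1ccc(C(=O)NO)cc1)c1ncc(-c2ccc(C)cc2)s1` gives 4300 nM in this assay, and compound 3 `CCCCCCN(Cc1ccc(C(=O)NO)cc1)c1ncc(-c2ccc(C)cc2)s1` gives 7420 nM. The step of a 7.9-fold lower number from compound 1 to compound 2 (0.90 log units; beyond the scatter) and the step of a 4.6-fold lower number from compound 1 to compound 3 (0.66 log units; beyond the scatter) both point the same way: exchanging the aromatic group on that nitrogen-bound carbon for a chain lowers the number. Between the two chains themselves the step of a 1.7-fold higher number from compound 2 to compound 3 (0.24 log units; within the scatter) shows no firm difference.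

Compound 4 `Cc1ccc(-c2cnc(N(Cc3ccc(C(=O)NO)cc3)C(C)C)s2)cc1` makes a related but shorter change: isopropyl in place of benzyl on a nitrogen on an aromatic ring. Within the data shown here, because both the step of a 7.9-fold lower number from compound 1 to compound 2 (0.90 log units; beyond the scatter) and the step of a 4.6-fold lower number from compound 1 to compound 3 (0.66 log units; beyond the scatter) lowered the number when a non-aromatic group replaced the aromatic one, a drop of comparable size is expected here, with the caveat that this rests on only two steps. Compound 4 is therefore estimated to give about 6000 nM in this assay, within a range from 2000 nM to 18000 nM, which would be a step of a 5.7-fold lower number from compound 1 to compound 4 (0.75 log units; beyond the scatter).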

Compound 4, concentration for 50% growth inhibition: 2180 nM
Compound 4: middle estimate off by 2.8-fold (0.44 log units), on the high side; the measured number falls inside the stated range.
By their numbers in this assay, from the lowest: compounds 4, 2 and 3 (each within the scatter of the next, the first and the last beyond it); then compound 1.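

With isopropyl on the nitrogen on an aromatic ring, the step of a 16-fold lower number from compound 1 to compound 4 (1.19 log units; beyond the scatter) in this assay shows that the whole benzyl group can give way to a small branched group with no ring, and that the gain seen with straight chains is not tied to their length. Against the butyl chain, the step of a 2.0-fold lower number from compound 2 to compound 4 (0.30 log units; within the scatter) shows no firm difference, whereas against the hexyl chain, the step of a 3.4-fold lower number from compound 3 to compound 4 (0.53 log units; beyond the scatter) is a real gap. Among these four compounds, then, every group without a ring gives a lower number than benzyl, and a group of only 3 heavy atoms is enough for the lowest tier, shared by compound 4 and compound 2. No measurement here explains why these groups differ at this position.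

From the compounds shown here alone, it remains open whether a still smaller group such as methyl or ethyl would keep or lose this level, and whether a ring without aromatic character, such as cyclohexyl, would behave like benzyl or like the chains. A chain ending in an amine or a carboxylic acid at this nitrogen is also an open case.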